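Thiosemicarbazone series: aromatic substituent changes on the shared core

The compounds below may be only part of what the source reports. "The series", "measured", "known", "first", "only" and "open" are said of these compounds alone.

Measured so far:
compound 1 `CC1=CC[C@H](C(C)(C)NC(=S)N/N=C/c2ccccc2)CC1`: 47600 nM
compound 2 `COc1ccc(/C=N/NC(=S)NC(C)(C)[C@H]2CC=C(C)CC2)cc1`: 30700 nM

In a functional assay on K562 cells (Homo sapiens) for inhibition, read by sulforhodamine B assay, with a stated time of 48 h (a higher number here means a weaker inhibitor of growth, a lower number a stronger inhibitor of growth), compound 1 gives 47600 nM, the higher of the two numbers shown; the nearest is compound 2, which gives 30700 nM, and the gap a 1.6-fold lower number from compound 1 to compound 2 (0.19 log units; within the scatter) lies within the scatter, so the two cannot be told apart. Compound 3 `CC1=CC[C@H](C(C)(C)NC(=S)N/N=C/c2cccc([N+](=O)[O-])c2)CC1` is not yet measured. It differs from compound 1 by nitro in place of hydrogen on an aromatic carbon. For the measured compounds named here, the only measured step that bears on a change at an aromatic carbon of this ring is a 1.6-fold lower number from compound 1 to compound 2 (0.19 log units; within the scatter), a methoxy in place of hydrogen, and it stayed within the scatter. On that basis no step beyond the scatter is expected in this assay for compound 3, in either direction; the expected step of a 1.2-fold lower number from compound 1 to compound 3 (0.08 log units; within the scatter) is small. Compound 3 is therefore estimated at 40000 nM, with a range from 15000 nM to 110000 nM.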

Compound 3, concentration for total growth inhibition: > 100000 nM
Compound 3: a limit, no number; the forecaster's own chance of this, stated with the estimate: 5%; middle value at least 2.5-fold (0.39 log units) away from the limit.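

In this assay, nitro in place of hydrogen on an aromatic carbon, meta to a large group, gives an at least 2.1-fold higher number from compound 1 to compound 3 (0.32 log units; beyond the scatter), which shows that a change on this aromatic ring can weaken growth inhibition. The methoxy change gives a 1.6-fold lower number from compound 1 to compound 2 (0.19 log units; within the scatter), so substitution on this ring is not neutral in every case, and the outcome depends on the group, its place, or both. Compound 3 carries a limit of the assay, not a number: the limit of > 100000 nM in this assay, at which 1 of the 3 values shown sits.

As far as these compounds go, how far the step from nitro extends remains open, since the limit sets no upper end to it. Also open, from the compounds shown here alone, is whether an amine or a carboxylic acid at the same place, or nitro elsewhere on the ring, would shift the number in the same direction.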